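Replacing butoxy with bromo: an expected antiproliferative step

The source may hold more compounds than are shown below. What is called first, only, known or untested is meant among the compounds shown, and "the series" means these compounds.

Measured in a functional assay on A549 cells (Homo sapiens) for antiproliferative activity, read by MTT assay, with a stated time of 48 h; a higher number here means a weaker inhibitor, a lower number a stronger inhibitor:
compound 1 `COc1ccc(/C=C/c2cc(OC)cc(OC)c2/C=C/C(=O)c2ccc(C)cc2)cc1`: 3.6 ug/mL
compound 2 `CCCCOc1ccc(C(=O)/C=C/c2c(/C=C/c3ccc(OC)cc3)cc(OC)cc2OC)cc1`: 8.7 ug/mL

Of the two numbers available in this assay, the higher belongs to compound 2 at 8.7 ug/mL, which makes it the weaker inhibitor of the pair. Within the data shown here, its only neighbour is compound 1, and the gap between them lies beyond the scatter.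

The unmeasured compound 3 `COc1ccc(/C=C/c2cc(OC)cc(OC)c2/C=C/C(=O)c2ccc(Br)cc2)cc1` keeps the shared core and changes one group: bromo in place of butoxy on an aromatic carbon. Bromo takes the place of butoxy on an aromatic carbon, para to a large group.

Among the measured compounds shown here, only one measured step bears on this change. It is a 2.4-fold higher number from compound 1 to compound 2 (0.38 log units; beyond the scatter), a modest step that came with butoxy replacing methyl on the same carbon. Compound 3 also lacks the butoxy, so a modest move toward a lower number is expected. For the measured compounds named here, no bromo compound has been measured yet, and one step is thin support, so the size remains uncertain. The estimated step is a 1.9-fold lower number from compound 2 to compound 3 (0.29 log units; within the scatter), which may not clear the scatter. Compound 3 is expected at about 4.5 ug/mL, with an estimated range of 2 ug/mL to 11 ug/mL.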

Compound 3, half-maximal inhibitory concentration: 8.3 ug/mL
Compound 3: middle estimate off by 1.8-fold (0.27 log units), on the low side; low and high end bracket the measured number.
By their numbers in this assay, from the lowest: compound 1; then compounds 3 and 2 (each within the scatter of the next).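

In this assay the change from 4-butoxyphenyl to 4-bromophenyl gives a 1.0-fold lower number from compound 2 to compound 3 (0.02 log units; within the scatter) and so, on this aromatic carbon, bromo with its 1 heavy atom cannot be told apart from butoxy with its 5 heavy atoms. Taken alone, a 2.4-fold higher number from compound 1 to compound 2 (0.38 log units; beyond the scatter) left open whether the butoxy chain itself set compound 2 apart from compound 1, but compound 3 carries no chain and still shows a 2.3-fold higher number from compound 1 to compound 3 (0.36 log units; beyond the scatter) in the same direction, so among these three compounds only the methyl compound stands apart. The data offer no measured property of these groups that would account for this grouping.

From the compounds shown here alone, with only methyl, butoxy and bromo at this position, it remains open whether the lower number of compound 1 is particular to methyl or would also appear with another small group such as ethyl or chloro. Going by these compounds, it is equally open how an amine, a carboxylic acid or a longer chain such as octyloxy on this same carbon would read in this assay when set against these three compounds.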